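Sulfamoyl swapped for methoxy: estimating tolerated concentration

The source may hold more compounds than are shown below. What is called first, only, known or untested is meant among the compounds shown, and "the series" means these compounds.

Compound 1 (`COc1cc2nc([S+]([O-])CC(=O)Nc3ccc([N+](=O)[O-])cc3)nc(Nc3c(Cl)cc(/C=C/C#N)cc3Cl)c2cc1OC`): (92800 nM)
Compound 2 (`COc1cc2nc([S+]([O-])CC(=O)Nc3cccc(S(N)(=O)=O)c3)nc(Nc3c(Cl)cc(/C=C/C#N)cc3Cl)c2cc1OC`): (67800 nM)

Both values come from an ADME assay on MT4 cells (Homo sapiens) for cytotoxicity, read by MTT assay, with a stated time of 5 days (a lower number here means that less compound is tolerated, a higher number that more compound is tolerated), and are true numbers, not assay limits. Compound 2 (67800 nM) sits within the scatter of compound 1 (92800 nM), so repeat testing could not be expected to tell the two apart.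

The next compound, compound 3 (`COc1cccc(NC(=O)C[S+]([O-])c2nc(Nc3c(Cl)cc(/C=C/C#N)cc3Cl)c3cc(OC)c(OC)cc3n2)c1`), keeps everything in compound 2 except one group. It carries methoxy in place of sulfamoyl on an aromatic carbon, meta to a large group (methoxy in place of sulfamoyl on an aromatic carbon).

Going by the values given here, only one measured step bears on this change, and it is (a 1.4-fold lower number from compound 1 to compound 2 (0.14 log units; within the scatter)). That step also exchanged the substituted phenyl on the amide-type nitrogen, and it stayed inside the scatter. Among the compounds with values here, it is thin evidence, since no measured compound carries methoxy at this place. Even so, no shift beyond the scatter is expected in either direction in this assay.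

The expected step is (a 1.0-fold lower number from compound 2 to compound 3 (0.02 log units; within the scatter)). For compound 3 the estimated value is (65000 nM), with an expected range from (25000 nM) to (130000 nM).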

Compound 3, half-maximal cytotoxic concentration: >= 167000 nM
Compound 3 gave a limit, no number; the forecaster's own chance of this, stated with the estimate: 20%; middle value at least 2.5-fold (0.40 log units) away from the limit.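

Going by these compounds alone, the exchange of sulfamoyl for methoxy on this aromatic carbon gives the first step here that clears the scatter in this assay, with an at least 2.4-fold higher number from compound 2 to compound 3 (0.39 log units; beyond the scatter). The earlier step, from 4-nitrophenyl to 3-sulfamoylphenyl, stayed inside the scatter, so only now is there a sign that the group at this place can change how much compound the cells tolerate. The comparison with the other earlier compound is less firm, with an at least 1.7-fold higher number from compound 1 to compound 3 (0.25 log units; that floor lies within the scatter), so this floor alone does not set compound 3 apart from compound 1.

Going by these compounds, the value of compound 3 is a limit of the assay and not a number, so the full size of both steps stays open: the limit of >= 167000 nM in this assay, at which 1 of the 3 values shown sits. A plain hydrogen, an amine, a carboxylic acid or a longer chain such as ethoxy at this place would help show whether the step follows from the arrival of methoxy or from the departure of sulfamoyl.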